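A few compounds are considered here, and "the series" means these few. Any claim that something is new, unique, unknown or untested is made for them only; others in the source may bear on it.

Working notes on the series. Compound 1 `Fc1ccc(Cn2nnc3c(Br)cccc32)cc1` gives 1 mL/min/g in an ADME assay on microsomes from liver (Rattus norvegicus, strain Wistar) for metabolic stability, tested at 2.5 uM; a lower number here means slower removal, a higher number faster removal of the compound. Compound 2 `Clc1ccc(Cn2nnc3c(Br)cccc32)cc1` gives 2.2 mL/min/g in this assay. The change (fluoro in place of chloro on an aromatic carbon), placed para to a large group, made the step of a 2.2-fold lower number from compound 2 to compound 1 (0.34 log units; beyond the scatter).

Compound 3 `Clc1cc(Br)c2nnn(CC3CC3)c2c1` gives 1.1 mL/min/g in this assay; the difference between its core and the core of compound 2 is not broken down here.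

Compound 4 `Fc1cc(Br)c2nnn(CC3CC3)c2c1` carries the same kind of change, (fluoro in place of chloro on an aromatic carbon), but here the place is part of a fused system of two rings, meta to a bromo group, meta to a fused ring and para to a fused ring, so the surroundings are not the same. Because compound 3 gives 1.1 mL/min/g and the earlier change made a 2.2-fold lower number from compound 2 to compound 1 (0.34 log units; beyond the scatter), the step from compound 3 to compound 4 is expected to be a 1.6-fold lower number from compound 3 to compound 4 (0.20 log units; within the scatter), somewhat smaller than the earlier one. Compound 4 is therefore estimated at 0.7 mL/min/g in this assay, between 0.35 mL/min/g and 1.4 mL/min/g.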

Compound 4, intrinsic clearance in a liver preparation (reported as CLH), per the amount of preparation that the assay uses: 0.5 mL/min/g
The estimate for compound 4 lay 1.4-fold (0.15 log units) above the measured number; measured number inside the range.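

In this assay, fluoro in place of chloro on an aromatic carbon gives a 2.2-fold lower number from compound 3 to compound 4 (0.34 log units; beyond the scatter), here on a place that is part of a fused system of two rings. The change carries from one core to the other with no difference beyond the scatter: the same change on two cores in this assay, a 2.2-fold lower number (0.34 log units; beyond the scatter) from compound 2 to compound 1 and a 2.2-fold lower number (0.34 log units; beyond the scatter) from compound 3 to compound 4, 1.0-fold (0.00 log units) apart, within the scatter of two such steps. This rests on two cores and one assay, so it does not show that the step holds on other cores, nor why the two steps match.

Still open, as far as these compounds go, is whether the step keeps its size when the bromo group gives way to a nitrile or an amine. Also open, from the compounds shown here alone, is how groups other than fluoro and chloro, such as methoxy or trifluoromethyl, behave at these places.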